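Changing the ring on a slowly cleared amide

The compounds below may be only part of what the source reports. "The series", "measured", "known", "first", "only" and "open" are said of these compounds alone.

In an ADME assay on microsomes from liver (Homo sapiens) for metabolic stability (on this read-out higher numbers stand for fast clearance and lower numbers for slow clearance), the results so far are:
- compound 1 `C[C@H](NC(=O)Cn1nnc2ccccc2c1=O)c1ccc(F)cc1` gives 31 mL/min/kg as a number
- compound 2 `Cc1ccc([C@H](C)NC(=O)Cn2nnc3ccccc3c2=O)cn1` gives < 9.9 mL/min/kg as a limit

For compound 2 the figure < 9.9 mL/min/kg is a limit and not a number.

Going by the values given here, the next molecule is compound 3 `C[C@H](NC(=O)Cn1nnc2ccccc2c1=O)c1ccn(C)n1` which keeps the shared core and changes only one ring 1-methyl-1H-pyrazol-3-yl in place of 6-methylpyridin-3-yl on a saturated chain carbon bound to an amide-type nitrogen and a saturated chain carbon in the same place as the earlier swap. Just one measured step bears on this place, and it lies beyond the scatter: an at least 3.1-fold lower number from compound 1 to compound 2 (0.49 log units; beyond the scatter) with its full size unknown. That step replaced 4-fluorophenyl with 6-methylpyridin-3-yl, so the new 1-methyl-1H-pyrazol-3-yl ring has not been tested by any measurement. Any shift in this assay could go either way in principle, but a rise is the main risk, since compound 1 at 31 mL/min/kg shows that faster clearance occurs with a different group here. The expected change is an at least 1.1-fold higher number from compound 2 to compound 3 (0.04 log units; that floor lies within the scatter) and so no step beyond the scatter is expected. In this assay the estimate for compound 3 is 11 mL/min/kg within an expected range of 6 mL/min/kg to 20 mL/min/kg for this measurement.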

Compound 3, clearance: 12 mL/min/kg
Estimate against measurement, compound 3: 1.1-fold (0.04 log units) below; measured number inside the range.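

In this assay, the pyrazole ring of compound 3 gives a 2.6-fold lower number from compound 1 to compound 3 (0.41 log units; beyond the scatter). This shows that a lower clearance than that of compound 1 is not tied to the 6-methylpyridin-3-yl ring: a five-membered aromatic ring with 2 hetero atoms also gives it at this position, on a saturated chain carbon bound to an amide-type nitrogen and a saturated chain carbon. The comparison between the two newer rings is looser, at an at least 1.2-fold higher number from compound 2 to compound 3 (0.08 log units; that floor lies within the scatter), and its size stays open, so the data do not rank these two rings; compound 2 stands at a limit, not a number: the limit of < 9.9 mL/min/kg in this assay, at which 1 of the 3 values shown sits.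

The compounds shown leave open whether the lower clearance comes with the hetero atoms in the new rings or simply with the loss of the 4-fluorophenyl group, and a plain phenyl ring at this position would help separate the two. They also leave open how much the methyl on each ring contributes, a question that a pyridin-3-yl ring or a 1H-pyrazol-3-yl ring without that methyl would address.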